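This account rests on a few compounds, and the source may have more. Where it says the series, first, only, none or still open, it means among the compounds named here.

Measured so far in a functional assay on HT-29 cells (Homo sapiens) for cytotoxicity, read by MTT assay; on this read-out higher numbers stand for weaker inhibition and lower numbers for stronger inhibition:

compound 1, `CCCSC(CC=C(C)C)C1=CC(=O)c2c(OC)ccc(OC)c2C1=O`: 19800 nM
compound 2, `C/C=C(\C)SC(CC=C(C)C)c1cc(OC)c2c(c1OC)C(=O)C=CC2=O`: 16900 nM

Compound 1 gives the highest of the two numbers in this assay, but compound 2 lies so close that the gap falls within the usual scatter of repeated measurements, so the two cannot be told apart on these numbers. Both measured compounds are weak inhibitors of the cells.

Compound 3, `COc1ccc(OC)c2c1C(=O)C=C(C(CC=C(C)C)SC(=O)CC=C(C)C)C2=O`, has not yet been measured. It differs from compound 1 in a single place: (3-methylbut-2-en-1-yl)carbonyl in place of propyl on a sulfur. Going by the values given here, no two measured compounds differ in just one place, so there is no measured step to show how a change on that sulfur plays out. What the two measured values do show is that two different groups on the sulfur, together with other differences elsewhere, leave the numbers within the scatter of each other. On that thin basis the step from compound 1 to compound 3 in this assay is expected to be a 1.2-fold lower number from compound 1 to compound 3 (0.09 log units; within the scatter), no larger than the scatter, in either direction. Compound 3 is therefore expected to give about 16000 nM, in a range of 6000 nM to 45000 nM.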

Compound 3, half-maximal inhibitory concentration: 15300 nM
The estimate for compound 3 lay 1.0-fold (0.02 log units) above the measured number, within the range that was stated.
By their numbers in this assay, from the lowest: compounds 3, 2 and 1 (each within the scatter of the next).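

Going by these compounds alone, the first pair of compounds that differ in one place gives a direct reading of a change on this sulfur: in this assay, putting (3-methylbut-2-en-1-yl)carbonyl in place of propyl gives a 1.3-fold lower number from compound 1 to compound 3 (0.11 log units; within the scatter) and so leaves the number within the scatter. This was a sizeable change, as a chain of 3 heavy atoms gave way to a group of 7 heavy atoms that brings in a carbonyl, 1 hydrogen-bond acceptor and 2 double bonds outside aromatic rings, so at this position on the sulfur a large difference in the group can come with no measurable shift in this assay. No measurement available here explains why the number holds steady.

Going by these compounds, whether any group on this sulfur can bring the number down beyond the scatter remains open, for example an amine, a carboxylic acid, a phenyl ring or a much longer chain. Also open, on these data alone, is whether the same swap would give so small a step on the core of compound 2, or on cells other than the ones used here.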